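The source may report more compounds than this note shows. Statements on the series, on what has been measured and on what is new or still open speak of the compounds shown alone.

Measured so far in an ADME assay on microsomes from liver (Rattus norvegicus) for metabolic stability; a lower number here means slower removal, a higher number faster removal of the compound:
- compound 1 `O=C(O)CCNC(=O)c1ccc(C(Oc2ccc(-n3cc(C(F)(F)F)cn3)cc2)C2CCC2)cc1`: < 25 mL/min/kg
- compound 2 `CCC(Oc1ccc(-n2cc(C(F)(F)F)cn2)cc1)c1ccc(C(=O)NCCC(=O)O)cc1`: < 25 mL/min/kg

Both values are limits of this assay, not numbers. Compound 1 sits at the limit < 25 mL/min/kg. Compound 2 likewise sits at the limit < 25 mL/min/kg. The step that the two limits leave unreadable from compound 1 to compound 2 therefore cannot be read, and the limit of < 25 mL/min/kg in this assay, at which 2 of the 2 values shown sit, is the whole of what the two measurements show.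

Compound 3 `CC(C)CC(Oc1ccc(-n2cc(C(F)(F)F)cn2)cc1)c1ccc(C(=O)NCCC(=O)O)cc1` differs from compound 2 by isopropyl in place of methyl on a saturated chain carbon, two bonds along the chain from an aromatic carbon and an oxygen on an aromatic ring. Among the measured compounds shown here, no measured step bears on this change, so no size or direction beyond the scatter can be argued for it. Compound 3 is estimated at 20 mL/min/kg (range 8 mL/min/kg to 50 mL/min/kg), an expected step that the limit leaves unreadable from compound 2 to compound 3, most likely reported again as a limit.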

Compound 3, clearance: 46 mL/min/kg
Beside the measured number, compound 3's estimate is 2.3-fold (0.36 log units) below it; the range from low to high includes it.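

In this assay, compound 3 gives the first number rather than a limit for this position, the other two values sitting at one: the limit of < 25 mL/min/kg in this assay, at which 2 of the 3 values shown sit. Isopropyl in place of methyl gives an at least 1.8-fold higher number from compound 2 to compound 3 (0.26 log units; that floor lies within the scatter), and isobutyl in place of cyclobutyl gives an at least 1.8-fold higher number from compound 1 to compound 3 (0.26 log units; that floor lies within the scatter). Both sizes are floors only, so the branched chain is not yet shown to differ beyond the scatter.

As far as these compounds go, how far compound 1 and compound 2 lie under their limit stays open. So does the reading in this assay for a longer unbranched chain or an amine at this position.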